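Cyano for Trifluoromethyl in Two Inactive Triazole Amides

The source may report more compounds than this note shows. Statements on the series, on what has been measured and on what is new or still open speak of the compounds shown alone.

Measured compounds:
compound 1 `Cc1ccc(-n2cc(CNC(=O)c3cccc4c3cnn4C(C)C)nn2)c(C)c1`: > 40000 nM
compound 2 `CC(C)n1ncc2c(C(=O)NCc3cn(Cc4ccc(C(F)(F)F)cc4)nn3)cccc21`: > 40000 nM

Both compounds carry the same amide-linked core and differ only in the group hanging from the triazole nitrogen. In a functional assay on MGC-803 cells (Homo sapiens) for inhibition, read by MTT assay, with a stated time of 72 h (a higher number here means a weaker inhibitor, a lower number a stronger inhibitor), compound 1 gives > 40000 nM, which is a limit of the assay and not a number. In this assay compound 2 likewise gives > 40000 nM, again a limit rather than a measured value. Compound 2 therefore stands at the limit of > 40000 nM in this assay, at which 2 of the 2 values shown sit, and nothing shown separates it from compound 1.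

Compound 3 `CC(C)n1ncc2c(C(=O)NCc3cn(Cc4ccc(C#N)cc4)nn3)cccc21` is the next compound, differing from compound 2 in one place: cyano in place of trifluoromethyl on an aromatic carbon. Within the data shown here, no pair of measured compounds shows what such a swap does here, so the direction of the step cannot be read from the data. The expectation is a step of a number no higher from compound 2 to compound 3 (the limit leaves the size open), that is, none beyond the scatter. For compound 3 the estimate in this assay is 40000 nM, with a range from 12000 nM to 120000 nM, and most likely the assay will once more report only a limit.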

Compound 3, half-maximal inhibitory concentration: 39600 nM
The estimate for compound 3 lay 1.0-fold (0.00 log units) above the measured number; the range from low to high includes it.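

In this assay, among these compounds, compound 3 gives 39600 nM, the only actual number among the three compounds, so a change on the aromatic carbon para to a large group can bring a reading inside the range of the assay. Cyano in place of trifluoromethyl gives a number no higher from compound 2 to compound 3 (the limit leaves the size open), and 4-cyanobenzyl in place of 2,4-dimethylphenyl on the aromatic nitrogen gives a number no higher from compound 1 to compound 3 (the limit leaves the size open); neither step can be read for size, and the result shows no more than that compound 3 yields a number where the other two yield a limit. The set as a whole remains close to where it began, with most of its values still limits: the limit of > 40000 nM in this assay, at which 2 of the 3 values shown sit.

The compounds shown leave open whether any group on this aromatic carbon, such as an amine, a carboxylic acid or a methoxy group, would give a number clearly lower than that of compound 3. They also leave open what a longer chain between the triazole nitrogen and the aromatic ring would do, and how far changes to the shared core would move the reading.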